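Changing the Sulfur Substituent of Compound 1

The source may hold more compounds than are shown below. What is called first, only, known or untested is meant among the compounds shown, and "the series" means these compounds.

In a functional assay on DU-145 cells (Homo sapiens) for inhibition, read by trypan blue exclusion, with a stated time of 96 h (on this read-out lower numbers stand for stronger inhibition of growth and higher numbers for weaker inhibition of growth), compound 1 (`O=C(/C(=C\c1ccc(Br)cc1)SCc1ccc(Cl)cc1)c1ccc(Br)cc1`) gives 1000 nM. Compound 2 (`COc1ccc(/C=C(/SCc2ccc(Cl)cc2)C(=O)c2ccc(Br)cc2)cc1O`) gives 1000 nM and compound 3 (`O=C(/C(=C\c1ccc(Br)cc1)SCc1ccc(Cl)cc1)c1ccc(Cl)cc1`) gives 1000 nM, so compound 1 stands level with both. Compound 4 (`O=C(/C(=C\c1ccc(Br)cc1)Sc1ccccc1Br)c1ccc(Br)cc1`) has not yet been measured. It differs from compound 1 in one place: 2-bromophenyl in place of 4-chlorobenzyl on a sulfur. In words, it has 2-bromophenyl in place of 4-chlorobenzyl on a sulfur.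

Two measured steps offer indirect guidance. Putting 3-hydroxy-4-methoxyphenyl in place of 4-bromophenyl gave no change at the digits printed from compound 1 to compound 2 (within the scatter), and putting chloro in place of bromo gave no change at the digits printed from compound 1 to compound 3 (within the scatter). Neither step touches the group on sulfur, so no measurement here tests this change directly. With only these two steps to go on, no shift in either direction can be predicted. The expected step is no change at the digits printed from compound 1 to compound 4 (within the scatter), meaning none beyond the scatter. On these data alone, the estimated value for compound 4 is 1000 nM, with an expected range from 350 nM to 3500 nM, kept wide since the change is untested.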

Compound 4, concentration for 50% growth inhibition: 1000 nM
For compound 4 middle estimate and measured number coincide at the digits printed; measured number inside the range.
By their numbers in this assay, from the lowest: compounds 1, 2, 3 and 4 (each within the scatter of the next).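

In this assay, among these compounds, the swap on the sulfur gives no change at the digits printed from compound 1 to compound 4 (within the scatter), so this position now has a measured change of its own, whereas the earlier steps left the group on sulfur untouched. Among the compounds shown here, the change is not a small one in name: 4-chlorobenzyl leaves and 2-bromophenyl enters, yet both carry one six-membered aromatic ring of carbon only and neither has a hydrogen-bond donor or acceptor, so this step tests only one swap between two such groups. Nothing measured here explains why the number holds across this swap.

The compounds shown leave open whether a group of a different kind on the sulfur, such as an amine, a carboxylic acid or a longer alkyl chain without a ring, would shift the number. They also leave open whether any change at this position can move it beyond the scatter.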